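Benzofuran for furan on two nucleoside cores

A few compounds are considered here, and "the series" means these few. Any claim that something is new, unique, unknown or untested is made for them only; others in the source may bear on it.

Working notes on the series. In a functional assay on HepG2 cells (Homo sapiens) for antiproliferative activity, read by XTT assay, with a stated time of 72 h (a lower number here means a stronger inhibitor, a higher number a weaker inhibitor), compound 1 `O=c1[nH]cnc2c1c(-c1ccoc1)cn2[C@@H]1O[C@H](CO)[C@@H](O)[C@H]1O` gives 12100 nM. Compound 3 `O=c1[nH]cnc2c1c(-c1cc3ccccc3o1)cn2[C@@H]1O[C@H](CO)[C@@H](O)[C@H]1O` differs from compound 1 by the change (1-benzofuran-2-yl in place of furan-3-yl on an aromatic carbon). In this assay compound 3 gives only a limit, > 20000 nM. The measured step is an at least 1.6-fold higher number from compound 1 to compound 3 (0.21 log units; that floor lies within the scatter); its floor comes from the limit of > 20000 nM in this assay, at which 2 of the 3 values shown sit.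

Compound 2 `Cc1nc(N)c2c(-c3ccoc3)cn([C@@H]3O[C@H](CO)[C@@H](O)[C@H]3O)c2n1` rests on a second core; the difference between the two cores of compound 1 and compound 2 is not broken down here. In this assay compound 2 gives only a limit, > 20000 nM.

Compound 4 `Cc1nc(N)c2c(-c3cc4ccccc4o3)cn([C@@H]3O[C@H](CO)[C@@H](O)[C@H]3O)c2n1` carries the change (1-benzofuran-2-yl in place of furan-3-yl on an aromatic carbon). Among the measured compounds shown here, the place given for this change is word for word the one given for compound 1 to compound 3, so this is the same change on the second core. The measured example of it went from a number to a limit; the starting point here, compound 2, already sits at the limit of this assay, so no numerical step can be expected to show. For compound 4 the expected step is a step that the limit leaves unreadable from compound 2 to compound 4, set beside the measured at least 1.6-fold higher number from compound 1 to compound 3 (0.21 log units; that floor lies within the scatter). Compound 4 is expected at 35000 nM, within 15000 nM to 100000 nM, and most probably this assay will again report only a limit for compound 4.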

Compound 4, half-maximal inhibitory concentration: > 20000 nM
Compound 4 ended at the assay's limit (the forecaster's own chance of this, stated with the estimate: 85%); the middle value does not contradict the limit.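

In this assay compound 2 and compound 4 both give only a limit, so no step between them can be read, because neither carries a number: the limit of > 20000 nM in this assay, at which 3 of the 4 values shown sit.

Open remains what 1-benzofuran-2-yl in place of furan-3-yl does on the core of compound 2, and how the two cores compare, with compound 1 the only one of the series that gives a number.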